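Acetyl to isopropylcarbonyl on compound 2

The compounds below may be only part of what the source reports. "The series", "measured", "known", "first", "only" and "open" are said of these compounds alone.

Values in a functional assay on Huh-5-2 cells (Homo sapiens), read by MTT assay; a higher number here means that more compound is tolerated, a lower number that less compound is tolerated:
- compound 1 `O=C(O)c1ccc2c(c1)nc(-c1ccc(OCc3cc(C(=O)NCCO)ccc3-c3ccc(Cl)cc3)cc1F)n2C1CCCCC1`: 26000 nM
- compound 2 `CC(=O)N(C)c1ccc(-c2ccc(Cl)cc2)c(COc2ccc(-c3nc4cc(C(=O)O)ccc4n3C3CCCCC3)c(F)c2)c1`: 26000 nM

Compound 2 stands level with compound 1 in this assay on these numbers. Compound 3 `CC(C)C(=O)N(C)c1ccc(-c2ccc(Cl)cc2)c(COc2ccc(-c3nc4cc(C(=O)O)ccc4n3C3CCCCC3)c(F)c2)c1` carries isopropyl in place of methyl on a carbonyl carbon and is not yet measured. Among the compounds with values here, only one measured step bears on this: no change at the digits printed from compound 1 to compound 2 (within the scatter) and it introduced the acetyl(methyl)amino group now being altered. Within the data shown here, no measured pair tests the change itself, so this evidence is thin. The expected outcome is no change at the digits printed from compound 2 to compound 3 (within the scatter) with no shift beyond the scatter in either direction. Compound 3 is estimated at 26000 nM (expected range 13000 nM to 50000 nM).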

Compound 3, half-maximal cytotoxic concentration: 22000 nM
The estimate for compound 3 lay 1.2-fold (0.07 log units) above the measured number, and the stated range covers the measured number.
By their numbers in this assay, from the lowest: compounds 3, 1 and 2 (each within the scatter of the next).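

In this assay, within the data shown here, isopropyl in place of methyl on a carbonyl carbon gives a 1.2-fold lower number from compound 2 to compound 3 (0.07 log units; within the scatter) and is the first direct test of this position, where the larger group is tolerated within the scatter. Placing (isopropylcarbonyl)(methyl)amino where compound 1 has (2-hydroxyethyl)carbamoyl gives a 1.2-fold lower number from compound 1 to compound 3 (0.07 log units; within the scatter) and likewise does not separate the two compounds. Nothing measured offers an explanation for these results.
Still open, as far as these compounds go, is whether an amine, a carboxylic acid or a longer chain on this carbonyl carbon would move the number beyond the scatter.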